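This account rests on a few compounds, and the source may have more. Where it says the series, first, only, none or still open, it means among the compounds named here.

Among the measured compounds shown here, compound 1 `c1cc(C2=NCCN2)cc(-c2cc3ccc(C4=NCCN4)cc3o2)c1` is the only compound here with an actual number: in an ADME assay on L6 cells (Rattus norvegicus) for cytotoxicity (on this read-out lower numbers stand for stronger inhibition and higher numbers for weaker inhibition), compound 1 gives 12800 nM. Compound 2 `CC(C)NC(=N)c1ccc(-c2cc3cc(C(=N)NC(C)C)ccc3o2)c(O)c1` is reported only as a limit, > 183000 nM. Compound 3 `COc1cc(C(=N)NC(C)C)ccc1-c1cc2ccc(C(=N)NC(C)C)cc2o1`, which carries a methoxy, is also reported only as a limit, > 181000 nM. Compound 4 `COc1ccc(C2=NCCN2)cc1-c1cc2ccc(C3=NCCN3)cc2o1` keeps the core of compound 1 but has methoxy in place of hydrogen on an aromatic carbon, ortho to a large group and para to a group of 5 heavy atoms (methoxy in place of hydrogen on an aromatic carbon). For the measured compounds named here, no measured pair isolates this change, so only a modest expected move toward weaker inhibition in this assay is proposed, a 2.0-fold higher number from compound 1 to compound 4 (0.29 log units; within the scatter). For compound 4 the estimated value is 25000 nM, with an expected range of 7000 nM to 90000 nM.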

Compound 4, half-maximal inhibitory concentration: 11100 nM
The estimate for compound 4 lay 2.3-fold (0.35 log units) above the measured number; measured number inside the range.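

In this assay, methoxy in place of hydrogen on an aromatic carbon, ortho to a large group and para to a group of 5 heavy atoms, gives a 1.2-fold lower number from compound 1 to compound 4 (0.06 log units; within the scatter). Among the compounds shown here, this is the first pair to isolate the change, and at this position the read-out does not separate methoxy from hydrogen. The compounds shown offer nothing that explains this result. On these data alone, it remains open whether an amine, a carboxylic acid or a longer chain at the same position would shift the number beyond the scatter.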